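Six-Membered Lactone Exchanged for a Five-Membered One

This account rests on a few compounds, and the source may have more. Where it says the series, first, only, none or still open, it means among the compounds named here.

Compound 1 `CC(=O)O[C@H](C[C@@H](O)C[C@H](O)/C=C/c1ccccc1)C[C@H]1CC=CC(=O)O1`: > 50000 nM
Compound 2 `CC(=O)O[C@H](C[C@H](C[C@H](O)/C=C/c1ccccc1)OC(=O)O)C[C@H]1CC=CC(=O)O1`: > 50000 nM
Compound 3 `O=C1C=CC[C@H](C[C@H](O)C[C@@H](O)C[C@H](O)/C=C/c2ccccc2)O1`: 3200 nM

In a functional assay on RAW264.7 cells (Mus musculus) for inhibition, read by Griess assay, with a stated time of 18 h (on this read-out higher numbers stand for weaker inhibition and lower numbers for stronger inhibition), compound 1 gives > 50000 nM, which is a limit of the assay and not a number. Compound 2 likewise returns only a limit, > 50000 nM. Compound 3 gives 3200 nM. Among the compounds with values here, the one readable step is an at least 15-fold lower number from compound 1 to compound 3 (1.19 log units; beyond the scatter); the step that the two limits leave unreadable from compound 1 to compound 2 sits at the limit of > 50000 nM in this assay, at which 2 of the 3 values shown sit. Compound 4 `CC(=O)O[C@@H](C/C=C1/C=CC(=O)O1)C[C@@H](O)C[C@H](O)/C=C/c1ccccc1` differs from compound 1 by a group of 7 heavy atoms (5 carbon, 2 oxygen; one five-membered non-aromatic ring with 1 hetero atom) in place of a group of 7 heavy atoms (5 carbon, 2 oxygen; one six-membered non-aromatic ring with 1 hetero atom), on a saturated chain carbon, two bonds along the chain from an oxygen next to a carbonyl group. Within the data shown here, neither measured step touches this part of the molecule, so no measured step bears on the change, and compound 1 itself stands only at a limit. Compound 4 is therefore expected to sit near that limit again, a number no higher from compound 1 to compound 4 (the limit leaves the size open). Compound 4 is estimated at 50000 nM, within 10000 nM to 200000 nM.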

Compound 4, half-maximal inhibitory concentration: 3400 nM
Beside the measured number, compound 4's estimate is 15-fold (1.17 log units) above it, outside the stated range (below it).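

In this assay, the saturated chain carbon two bonds along the chain from an oxygen next to a carbonyl group proves a second place that matters: the five-membered ring in place of the six-membered one gives an at least 14-fold lower number from compound 1 to compound 4 (1.16 log units; beyond the scatter). Until now, only exchanging acetyl for hydrogen had brought a readable value. Compound 1 stands at a limit of the assay, so the true size of this step stays open: the limit of > 50000 nM in this assay, at which 2 of the 4 values shown sit.

As far as these compounds go, whether hydrogen in place of acetyl would add anything on the five-membered lactone remains open. So does whether an amine could take the acetyl's place.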